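The compounds below may be only part of what the source reports. "The series", "measured", "known", "first", "only" and "open" are said of these compounds alone.

Measured compounds in a functional assay on CCRF-CEM cells (Homo sapiens) for antiproliferative activity, read by MTT assay, with a stated time of 3 days; a lower number here means a stronger inhibitor, a higher number a weaker inhibitor:

Compound 1 `CCCCc1ccc(C#Cc2cn(C/C=C/CN3C(=O)c4ccccc4C3=O)c(=O)[nH]c2=O)cc1`: compound 1 gives 31000 nM
Compound 2 `O=C1c2ccccc2C(=O)N1C/C=C\Cn1cc(C#CCCc2ccccc2)c(=O)[nH]c1=O`: compound 2 gives 168000 nM
Compound 3 `O=C1c2ccccc2C(=O)N1C/C=C/Cn1cc(C#CCCc2ccccc2)c(=O)[nH]c1=O`: compound 3 gives 38000 nM

Compounds 2 and 3 share every atom and bond; the cores differ only as set out in the two compounds have the same atoms and bonds and differ only in configuration as drawn: 1 of 1 stereo elements differ; a double bond is drawn E in compound 3 and Z in compound 2. The step of a 4.4-fold lower number from compound 2 to compound 3 (0.65 log units; beyond the scatter) is the one clear separation in the set, and it rests on the fact that compounds 2 and 3 differ only in the configuration as drawn alone. Compound 2 stands with the highest number of the three, beyond the scatter from both compound 3 and compound 1.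

From compound 3 to compound 1 the change is 4-butylphenyl in place of phenethyl on a triple-bonded carbon, and the step of a 1.2-fold lower number from compound 3 to compound 1 (0.09 log units; within the scatter) does not leave the scatter. The two compounds therefore read as equivalent in this assay.

Compound 4 `CCCCc1ccc(C#Cc2cn(C/C=C\CN3C(=O)c4ccccc4C3=O)c(=O)[nH]c2=O)cc1` is not yet measured. It is made from compound 2 by 4-butylphenyl in place of phenethyl on a triple-bonded carbon, the same change as that from compound 3 to compound 1, at the same place. Among the measured compounds shown here, the expected step from compound 2 to compound 4 is therefore a 1.2-fold lower number from compound 2 to compound 4 (0.08 log units; within the scatter), essentially a repeat of the step from compound 3 to compound 1, resting on a 1.2-fold lower number from compound 3 to compound 1 (0.09 log units; within the scatter) as the only measured instance of this change. Because the starting point of compound 2 is 168000 nM, compound 4 is expected to remain a weak inhibitor, near its parent rather than near compound 1. The estimate for compound 4 in this assay is 140000 nM, with a range from 60000 nM to 350000 nM.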

Compound 4, half-maximal inhibitory concentration: 23000 nM
Estimate against measurement, compound 4: 6.1-fold (0.78 log units) above, outside the stated range (below it).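

In this assay, 4-butylphenyl in place of phenethyl on a triple-bonded carbon does not carry over from one core to the other with a constant size, since the new step is a 7.3-fold lower number from compound 2 to compound 4 (0.86 log units; beyond the scatter), and the two instances differ: the same change on two cores in this assay, a 1.2-fold lower number (0.09 log units; within the scatter) from compound 3 to compound 1 and a 7.3-fold lower number (0.86 log units; beyond the scatter) from compound 2 to compound 4, 6.0-fold (0.78 log units) apart, beyond the scatter of two such steps

With 4-butylphenyl in place, the drawn configuration of the double bond no longer separates the two compounds, the step being a 1.3-fold lower number from compound 1 to compound 4 (0.13 log units; within the scatter), whereas with phenethyl the step is a 4.4-fold lower number from compound 2 to compound 3 (0.65 log units; beyond the scatter), and this pair likewise carries only one difference: the fact that compounds 1 and 4 differ only in the configuration as drawn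

Among the compounds shown here, the size of this change therefore depends on the configuration of the double bond in these four compounds, but each configuration supplies only one pair, so no rule for other cores follows, and the numbers do not show why the two instances differ.

Open, from the compounds shown here alone, is whether this dependence on configuration is particular to phenethyl and 4-butylphenyl or also appears with other groups on the triple-bonded carbon, such as a longer chain in place of the butyl. Also open, going by these compounds, is how matched E and Z compounds would compare if an amine or a carboxylic acid stood at the end of that chain.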